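Leaving the 1-methylpiperidin-4-yl group: compound 2 to compound 3

A few compounds are considered here, and "the series" means these few. Any claim that something is new, unique, unknown or untested is made for them only; others in the source may bear on it.

In an ADME assay on Caco-2 cells (Homo sapiens) for permeability, read by LC-MS, in the apical to basolateral direction, with a stated time of 90 min (a lower number here means that the compound crosses the layer more slowly, a higher number that the compound crosses the layer faster), compound 2 (`COc1ncc(-c2cc(OC3CCN(C)CC3)c3ncnc(C)c3c2)cc1NS(=O)(=O)c1ccc(F)cc1F`) gives 4.5 10^-6 cm/s and stands lower of the two measured compounds, with compound 1 (`COc1ncc(-c2cc(OC3CCC3)c3ncnc(C)c3c2)cc1NS(=O)(=O)c1ccc(F)cc1F`) at 44 10^-6 cm/s on the same scale. Compound 3 (`COc1ncc(-c2cc(OC(F)F)c3ncnc(C)c3c2)cc1NS(=O)(=O)c1ccc(F)cc1F`) carries difluoromethyl in place of 1-methylpiperidin-4-yl on an oxygen on an aromatic ring. Among the compounds with values here, the only measured step bearing on this is a 9.8-fold lower number from compound 1 to compound 2 (0.99 log units; beyond the scatter) with that same group entering in place of cyclobutyl, beyond the scatter. Difluoromethyl itself has no measured precedent here. In this assay the expected change is upward and of similar or smaller size, estimated as a 6.2-fold higher number from compound 2 to compound 3 (0.79 log units; beyond the scatter) overall. For compound 3 the estimated value is 28 10^-6 cm/s (range 11 10^-6 cm/s to 60 10^-6 cm/s).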

Compound 3, apparent permeability: 34 10^-6 cm/s
Compound 3: middle estimate off by 1.2-fold (0.08 log units), on the low side; the range from low to high includes it.
By their numbers in this assay, from the lowest: compound 2; then compounds 3 and 1 (each within the scatter of the next).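

In this assay, within the data shown here, difluoromethyl on this oxygen gives a 7.6-fold higher number from compound 2 to compound 3 (0.88 log units; beyond the scatter), so the low number so far belongs to 1-methylpiperidin-4-yl alone among the three groups. Against cyclobutyl, difluoromethyl gives a 1.3-fold lower number from compound 1 to compound 3 (0.11 log units; within the scatter), so these two groups cannot be told apart at this position. Nothing available explains these numbers.

As far as these compounds go, whether the low number of compound 2 goes with the ring nitrogen or with the size of the group stays open. A tetrahydropyran-4-yl group or an open-chain dimethylaminoethyl group on the same oxygen would separate the two.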